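The source may hold more compounds than are shown below. What is called first, only, known or untested is meant among the compounds shown, and "the series" means these compounds.

Measured so far in a functional assay on MCF cells (Homo sapiens) for antiproliferative activity, with a stated time of 72 h; on this read-out lower numbers stand for stronger inhibition and higher numbers for weaker inhibition:
- compound 1 `COc1ccc(CNc2ncnc3c2ncn3[C@@H]2O[C@H](CO)[C@@H](O)[C@H]2O)c(OC)c1`: > 166000 nM, a limit
- compound 2 `OC[C@H]1O[C@@H](n2cnc3c(NCc4ccc(F)c(F)c4F)ncnc32)[C@H](O)[C@@H]1O`: > 166000 nM, a limit

Compound 2 has no number on this read-out, only the limit > 166000 nM. For the measured compounds named here, the series so far consists of the limit of > 166000 nM in this assay, at which 2 of the 2 values shown sit.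

The next compound is compound 3 `OC[C@H]1O[C@@H](n2cnc3c(NCc4c(F)ccc(F)c4F)ncnc32)[C@H](O)[C@@H]1O`. The change is 2,3,6-trifluorophenyl in place of 2,3,4-trifluorophenyl on a saturated chain carbon bound to a nitrogen on an aromatic ring; the two compounds have the same atoms, joined differently.

Going by the values given here, one measured step bears on this, as it changes the group at the same place, on a saturated chain carbon bound to a nitrogen on an aromatic ring. That step is a step that the two limits leave unreadable from compound 1 to compound 2, so it gives no size to carry over. With 2,4-dimethoxyphenyl and with 2,3,4-trifluorophenyl at this place, this assay returned only a limit.

The expectation therefore rests on compound 2 and its limit of > 166000 nM. The expected outcome in this assay is a number no higher from compound 2 to compound 3 (the limit leaves the size open), with no change beyond the scatter in either direction. A further limit is the most likely report. For compound 3 the estimate is 166000 nM, with an expected range of 50000 nM to 166000 nM.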

Compound 3, half-maximal inhibitory concentration: > 166000 nM
Compound 3 gave a limit, no number (the forecaster's own chance of this, stated with the estimate: 80%); the middle value sits exactly at the limit.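

In this assay compound 3 gives only a limit, > 166000 nM, so none of the steps among compound 1, compound 2 and compound 3 can be read. The series stays at a single limit: the limit of > 166000 nM in this assay, at which 3 of the 3 values shown sit.

The compounds shown leave open whether any group on this saturated chain carbon bound to a nitrogen on an aromatic ring gives a measurable number.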